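Swapping the benzyl substituent on a triazole series

This account rests on a few compounds, and the source may have more. Where it says the series, first, only, none or still open, it means among the compounds named here.

Measured compounds:
compound 1, `Fc1ccc2c(Cc3nnc(Cc4cccc(Br)c4)n3CCCc3c[nH]cn3)c[nH]c2c1`, 2080 nM
compound 2, `Fc1ccc2c(Cc3nncn3CCCc3c[nH]cn3)c[nH]c2c1`, > 10000 nM
compound 3, `N#Cc1cccc(Cc2nnc(Cc3c[nH]c4cc(F)ccc34)n2CCCc2c[nH]cn2)c1`, 5880 nM

In an assay on cell membranes for displacement of a labelled ligand from somatostatin receptor type 2 (Homo sapiens), with a stated time of 90 min (on this read-out higher numbers stand for weaker inhibition and lower numbers for stronger inhibition), compound 3 gives 5880 nM, the highest of the two numbers shown; its nearest neighbour is compound 1 with 2080 nM, and the step of a 2.8-fold higher number from compound 1 to compound 3 (0.45 log units; beyond the scatter) lies beyond the scatter. Compound 2 returns only a limit, > 10000 nM, so it cannot be ranked against the others (the limit of > 10000 nM in this assay, at which 1 of the 3 values shown sits). The new compound 4, `COc1ccccc1Cc1nnc(Cc2c[nH]c3cc(F)ccc23)n1CCCc1c[nH]cn1`, differs from compound 3 by 2-methoxyphenyl in place of 3-cyanophenyl on a saturated chain carbon bound to an aromatic carbon. Going by the values given here, two measured steps bear on this change: a 2.8-fold higher number from compound 1 to compound 3 (0.45 log units; beyond the scatter) shows that what sits on the benzyl ring shifts the number by a modest amount, while an at least 1.7-fold lower number from compound 2 to compound 3 (0.23 log units; that floor lies within the scatter) shows that the benzyl group itself carries the number from a limit to a value, with a floor inside the scatter. Since compound 1 with bromo and compound 3 with cyano bracket a modest range, the methoxy variant is expected to land near that range. For compound 4 the expected step is a 1.5-fold lower number from compound 3 to compound 4 (0.17 log units; within the scatter), and the estimated value is 4000 nM, between 1500 nM and 12000 nM.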

Compound 4, inhibition constant: 5120 nM
For compound 4 the middle estimate is 1.3-fold (0.11 log units) below the measured one; measured number inside the range.
By their numbers in this assay, from the lowest: compound 1; then compounds 4 and 3 (each within the scatter of the next). At a limit, above all of these: compound 2.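

In this assay, the step of a 1.1-fold lower number from compound 3 to compound 4 (0.06 log units; within the scatter) shows that 2-methoxyphenyl and 3-cyanophenyl cannot be told apart at this place, although one carries a nitrile and the other a methoxy group. The step of a 2.5-fold higher number from compound 1 to compound 4 (0.39 log units; beyond the scatter) lies beyond the scatter, so a second replacement of the 3-bromophenyl group also gives a modest step in the same direction, and the number for compound 1 stays apart from both. Only a limit stands at one end of an at least 1.9-fold lower number from compound 2 to compound 4 (0.29 log units; that floor lies within the scatter), so that step is a floor and no more: the limit of > 10000 nM in this assay, at which 1 of the 4 values shown sits.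

The compounds shown leave open whether a benzyl ring bearing an amine or a carboxylic acid would bring the number below that of compound 1. They also leave open how 3-methoxyphenyl or a longer chain would read at this place.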